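The source may hold more compounds than are shown below. What is called first, only, known or untested is meant among the compounds shown, and "the series" means these compounds.

Three chalcone-type compounds have been measured in an ADME assay on RAW264.7 cells (Mus musculus) for cytotoxicity, read by MTT assay, with a stated time of 24 h, tested at 5 ug/mL; on this read-out lower numbers stand for a stronger effect and higher numbers for a weaker effect at the one concentration tested. Compound 1, with the structure `COc1ccc(C(=O)/C=C/c2ccc(OC)c(OC)c2)c(O)c1`, gives 73.9% in this assay. Compound 2, with the structure `COc1ccc(CCC(=O)c2ccc(OC)c(OC)c2)cc1O`, gives 91.8% in this assay. Compound 3, with the structure `COc1ccc(C(=O)CCc2cccc(OC)c2OC)c(O)c1`, gives 92.7% in this assay.

On these numbers compound 3 stands at the top of the three, but compound 2 lies so close to it that the two fall within the usual scatter of repeated measurements and cannot be told apart. Only compound 1 is clearly separated, its number lying beyond the scatter below that of compound 3.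

Compound 4, with the structure `COc1ccc(C(=O)CCc2ccc(OC)c(OC)c2OC)c(O)c1`, has not yet been measured in this assay. It differs from compound 3 by one change: methoxy in place of hydrogen on an aromatic carbon. Going by the values given here, no measured pair shows what such a change does here, so nothing in the data points to a move in either direction. Because compound 3 gives 92.7% and compound 2 gives 91.8%, both near the weak end of the read-out, a step no larger than the scatter is expected from compound 3 to compound 4, namely a number 2.7 percentage points lower from compound 3 to compound 4 (within the scatter). Compound 4 is therefore estimated to give 90% in this assay, with a likely range from 78% to 99%.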

Compound 4, a percentage reported as activity, at one concentration (the size of the read-out at that concentration, not a potency): 94.8%
Beside the measured number, compound 4's estimate is 4.8 percentage points below it; the range from low to high includes it.
By their numbers in this assay, from the lowest: compound 1; then compounds 2, 3 and 4 (each within the scatter of the next).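

Going by these compounds alone, compound 4 gives the first direct reading of what methoxy in place of hydrogen on an aromatic carbon does in this assay, and the step is a number 2.1 percentage points higher from compound 3 to compound 4 (within the scatter), so compounds 3 and 4 cannot be told apart on this read-out. The new methoxy sits on a six-membered aromatic ring of carbon only, ortho to a methoxy group, meta to a methoxy group and para to a large group, and at this one place on this one core the added group brings no readable difference. No measurement at hand explains this result.

A single group at a single place says little about the position as a whole, and an amine, a carboxylic acid or a longer chain such as ethoxy at the same carbon could read differently. From the compounds shown here alone, it also remains open whether the same methoxy would leave the number just as unreadably changed on the core of compound 1, which gives 73.9% in this assay and has a different shared pattern of groups.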